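Notes on the series: one fluoro removed from compound 1

The compounds below may be only part of what the source reports. "The series", "measured", "known", "first", "only" and "open" are said of these compounds alone.

Measured so far:
compound 1, `CN(C(=O)NC(=O)c1c(F)cccc1F)c1nc(C(F)(F)F)c(C(=O)N/N=C/c2cc(C(F)(F)F)cc(C(F)(F)F)c2)s1`, 6.85 ug/mL
compound 2, `Cc1nc(N(C)C(=O)NC(=O)c2c(F)cccc2F)sc1C(=O)N/N=C/c1cc(C(F)(F)F)cc(C(F)(F)F)c1`, 11.6 ug/mL
compound 3, `CN(C(=O)NC(=O)c1c(Cl)cccc1Cl)c1nc(C(F)(F)F)c(C(=O)N/N=C/c2ccccc2C(F)(F)F)s1`, 6.24 ug/mL

In a functional assay on MCF7 cells (Homo sapiens) for inhibition, read by MTT assay, with a stated time of 72 h (a higher number here means a weaker inhibitor, a lower number a stronger inhibitor), compound 1 gives 6.85 ug/mL, the second highest of the three numbers; compound 3 stands nearest and compound 2 furthest, both within the scatter of compound 1. Among the measured compounds shown here, the single one-point step, a 1.7-fold higher number from compound 1 to compound 2 (0.23 log units; within the scatter), concerns another position and does not bear on the change followed here. Compound 4, `CN(C(=O)NC(=O)c1ccccc1F)c1nc(C(F)(F)F)c(C(=O)N/N=C/c2cc(C(F)(F)F)cc(C(F)(F)F)c2)s1`, differs from compound 1 by hydrogen in place of fluoro on an aromatic carbon. For the measured compounds named here, no measured pair shows this change, so no step beyond the scatter is expected in this assay in either direction. Compound 4 is therefore expected close to that value, at 8 ug/mL with a range of 3.5 ug/mL to 18 ug/mL, which is estimated as a step of a 1.2-fold higher number from compound 1 to compound 4 (0.07 log units; within the scatter).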

Compound 4, half-maximal inhibitory concentration: 6.16 ug/mL
Compound 4: middle estimate off by 1.3-fold (0.11 log units), on the high side, and the stated range covers the measured number.
By their numbers in this assay, from the lowest: compounds 4, 3, 1 and 2 (each within the scatter of the next).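

In this assay, among the compounds shown here, the change from 2,6-difluorophenyl to 2-fluorophenyl gives a 1.1-fold lower number from compound 1 to compound 4 (0.05 log units; within the scatter) and is the first measured pair for hydrogen in place of fluoro at this position. In this pair, the second fluoro makes no difference that can be read beyond the scatter. No evidence on hand bears on the reason for this result. Still open, going by these compounds, is whether a methoxy group or an amine at this position would also leave the number within the scatter. Also open, on these data alone, is whether losing the remaining fluoro, to give an unsubstituted phenyl, would do so.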